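Replacing the aromatic ring on the imine nitrogen with an open chain

The compounds below may be only part of what the source reports. "The series", "measured", "known", "first", "only" and "open" are said of these compounds alone.

Measured compounds:
compound 1 `CCOC(=O)C1=C(N/C=N/c2nnc(S(N)(=O)=O)s2)Nc2[nH]nc(C)c2C1c1ccc(N(C)C)cc1` — 26300 nM
compound 2 `CCOC(=O)C1=C(N/C=N/c2cccnc2Cl)Nc2[nH]nc(C)c2C1c1ccc(N(C)C)cc1` — 4630 nM
compound 3 `CCOC(=O)C1=C(N/C=N/c2ccccn2)Nc2[nH]nc(C)c2C1c1ccc(N(C)C)cc1` — 29200 nM

Of the compounds shown here, three sharing one core have been measured in a functional assay on HeLa cells (Homo sapiens) for inhibition, read by MTT assay, with a stated time of 48 h; a lower number here means a stronger inhibitor, a higher number a weaker inhibitor. Compound 1 stands second highest of the three numbers; compound 3 is nearest to it, and the two lie within the scatter of each other, while compound 2 is furthest, as the step of a 5.7-fold lower number from compound 1 to compound 2 (0.75 log units; beyond the scatter) shows. The remaining step, a 6.3-fold higher number from compound 2 to compound 3 (0.80 log units; beyond the scatter), is of similar size in the other direction, and a 1.1-fold higher number from compound 1 to compound 3 (0.05 log units; within the scatter) is within the scatter.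

Compound 4 `CCOC(=O)C1=C(N/N=C(/C#N)C(=O)OCC)Nc2[nH]nc(C)c2C1c1ccc(N(C)C)cc1` differs from compound 1 in one place: a group of 9 heavy atoms (5 carbon, 2 nitrogen, 2 oxygen; no ring) in place of a group of 11 heavy atoms (3 carbon, 4 nitrogen, 2 oxygen, 2 sulfur; one five-membered aromatic ring with 3 hetero atoms), on an amine nitrogen. Within the data shown here, each measured step swaps one aromatic ring for another on the double-bonded nitrogen, whereas here a chain with no ring enters, so no measured step bears directly on this change. Among the measured compounds shown here, the only guide is that two of the three ring swaps stayed within or near the scatter, and only compound 2 moved modestly. Compound 4 is therefore expected to remain close to compound 1, with an estimated step of a 1.1-fold lower number from compound 1 to compound 4 (0.02 log units; within the scatter). The estimated value for compound 4 is 25000 nM, with a range from 8000 nM to 70000 nM.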

Compound 4, half-maximal inhibitory concentration: 39200 nM
Compound 4: middle estimate off by 1.6-fold (0.20 log units), on the low side; the measured number falls inside the stated range.
By their numbers in this assay, from the lowest: compound 2; then compounds 1, 3 and 4 (each within the scatter of the next).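

In this assay the step of a 1.5-fold higher number from compound 1 to compound 4 (0.17 log units; within the scatter) and the step of a 1.3-fold higher number from compound 3 to compound 4 (0.13 log units; within the scatter) both lie within the scatter, so at this position the chain with no ring in compound 4 gives a number that cannot be told apart from those of the two ring-bearing compounds. Compound 2 alone stands apart, as an 8.5-fold higher number from compound 2 to compound 4 (0.93 log units; beyond the scatter) shows, and its steps to all three others lie beyond the scatter, which makes it the strongest inhibitor of the four. Nothing available explains why the 2-chloropyridin-3-yl group differs from the other groups here.

Going by these compounds, it remains open whether a simple amine or a carboxylic acid at this position would give a number like that of compound 4 or like that of compound 2. A pyridin-3-yl group without the chlorine would show whether the chlorine itself goes with the lower number of compound 2.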